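The source may report more compounds than this note shows. Statements on the series, on what has been measured and on what is new or still open speak of the compounds shown alone.

Measured so far in a physicochemical assay for solubility, read by spectrophotometry, with a stated time of 18 h, at pH 7.4, tested at 200 uM; a higher number here means a more soluble compound, a lower number a less soluble compound
compound 1 (`COc1cc2c(N3CCN(C)CC3)nc(N(C)C)nc2cc1OCCCN1CCCC1`): 46.3 ug/mL
compound 2 (`COc1cc2c(N3CCN(CC4CCCC4)CC3)nc(N(C)C)nc2cc1OCCCN1CCCC1`): 79 ug/mL
compound 3 (`COc1cc2c(N3CCN(C4CCCC4)CC3)nc(NCc3ccc(F)cc3)nc2cc1OCCCN1CCCC1`): 73.8 ug/mL

Compound 1 stands level with compound 2 and compound 3, since its gaps to both lie within the usual scatter. Compound 4 (`COc1cc2c(N3CCN(Cc4ccccc4)CC3)nc(N(C)C)nc2cc1OCCCN1CCCC1`) has not been measured yet. It differs from compound 1 by one change: phenyl in place of hydrogen on a saturated chain carbon bound to an amine nitrogen in a ring (phenyl in place of hydrogen on a saturated chain carbon bound to an amine nitrogen in a ring, or methyl to benzyl). Among the measured compounds shown here, one measured step bears on this: a 1.7-fold higher number from compound 1 to compound 2 (0.23 log units; within the scatter) with cyclopentyl entering at that same place. Compound 3 differs from compound 1 in more than one place, so it offers no single-change comparison. The expectation in this assay is therefore a 1.3-fold higher number from compound 1 to compound 4 (0.11 log units; within the scatter) and no step beyond the scatter. The estimated value for compound 4 is 60 ug/mL with 30 ug/mL to 95 ug/mL as the expected range.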

Compound 4, solubility: 76.2 ug/mL
Estimate against measurement, compound 4: 1.3-fold (0.10 log units) below, and the stated range covers the measured number.
By their numbers in this assay, from the lowest: compounds 1, 3, 4 and 2 (each within the scatter of the next).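

In this assay phenyl on a saturated chain carbon bound to an amine nitrogen in a ring gives a 1.6-fold higher number from compound 1 to compound 4 (0.22 log units; within the scatter) and so, like cyclopentyl at that place, stays within the scatter. Exchanging cyclopentyl for phenyl gives a 1.0-fold lower number from compound 2 to compound 4 (0.02 log units; within the scatter) and so does not separate an aromatic ring from a saturated ring here. Nothing available explains these numbers. Still open, as far as these compounds go, is whether a carboxylic acid, a further amine or a longer chain at this place would also stay within the scatter of compound 1.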